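This account rests on a few compounds, and the source may have more. Where it says the series, first, only, none or still open, it means among the compounds named here.

Measured so far:
- compound 1 `NC(=O)C[C@H](NC(=O)CN(c1nc(Cl)nc2c1ncn2C1CCCCO1)C1CC1)C(=O)OCc1ccccc1`: 35%
- compound 2 `O=C(CN(c1nc(Cl)nc2c1ncn2C1CCCCO1)C1CC1)N[C@@H](CCC(=O)OCc1ccccc1)C(=O)OCc1ccccc1`: 25.2%

In a functional assay on the whole organism with Mus musculus as the target, with a stated time of 90 min, at a dose of 25 umol/kg by the oral route (a higher number here means a stronger effect of the compound at the dose given, a lower number a weaker effect), compound 2 has the smaller of the two numbers, but the step of a number 9.8 percentage points lower from compound 1 to compound 2 (within the scatter) stays within the scatter, so the two compounds cannot be told apart. Compound 3 `CC(C)(C)OC(=O)NCCCC[C@H](NC(=O)CN(c1nc(Cl)nc2c1ncn2C1CCCCO1)C1CC1)C(=O)OCc1ccccc1` differs from compound 2 by 2-((tert-butoxycarbonyl)amino)ethyl in place of benzyloxycarbonyl on a saturated chain carbon, three bonds along the chain from an amide-type nitrogen and a carbonyl carbon. Within the data shown here, no measured step swaps a benzyloxycarbonyl for a tert-butoxycarbonylamino group; the only step known, from compound 1 to compound 2, changed a neighbouring side chain and was within the scatter. The expected step of a number 2.8 percentage points higher from compound 2 to compound 3 (within the scatter) is therefore none beyond the scatter. Compound 3 is estimated at 28%, within 12% to 45%.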

Compound 3, a percentage reported as activity, at one dose (the size of the read-out at that dose, not a potency): 32.9%
The estimate for compound 3 lay 4.9 percentage points below the measured number; the range from low to high includes it.
By their numbers in this assay, from the lowest: compounds 2, 3 and 1 (each within the scatter of the next).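

In this assay, 2-((tert-butoxycarbonyl)amino)ethyl in place of benzyloxycarbonyl gives a small change (a number 7.7 percentage points higher from compound 2 to compound 3 (within the scatter)), and 3-((tert-butoxycarbonyl)amino)propyl in place of carbamoyl gives another (a number 2.1 percentage points lower from compound 1 to compound 3 (within the scatter)). This position on the saturated chain carbon has now carried three different side chains, one with an aromatic ring and two without, and the numbers of all three compounds remain within the scatter of the next. No evidence is available that could account for this.

Still open, as far as these compounds go, is whether a free amine or a carboxylic acid at the end of this side chain would give a number beyond the scatter.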